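Nitro for bromo on the chalcone aryl ring: expected toxicity

The source may hold more compounds than are shown below. What is called first, only, known or untested is meant among the compounds shown, and "the series" means these compounds.

Compounds measured so far:
compound 1 `CN(C)c1ccc(/C=C/C(=O)c2ccc3c(c2O)C=CC(C)(C)O3)cc1`, > 400000 nM
compound 2 `CC1(C)C=Cc2c(ccc(C(=O)/C=C/c3ccc(Cl)cc3)c2O)O1`, 92200 nM
compound 3 `CC1(C)C=Cc2c(ccc(C(=O)/C=C/c3ccc(Br)cc3)c2O)O1`, "not determined" (no result reported)

Three compounds share one core and differ in the group on the aromatic carbon of the six-membered ring of carbon only. In an ADME assay on Vero cells (Chlorocebus sabaeus) for cytotoxicity, read by MTT assay, with a stated time of 72 h (on this read-out higher numbers stand for lower toxicity in this test and lower numbers for higher toxicity in this test), compound 1 gives only a limit, > 400000 nM, and the limit of > 400000 nM in this assay, at which 1 of the 3 values shown sits, marks it as such. Compound 2 gives 92200 nM in this assay. Among the compounds with values here, the one step that can be sized, an at least 4.3-fold lower number from compound 1 to compound 2 (0.63 log units; beyond the scatter), is at least modest. For compound 3 no number is known in this assay; its entry reads "not determined" (no result reported), so it stands nowhere on the scale shown.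

Compound 4 `CC1(C)C=Cc2c(ccc(C(=O)/C=C/c3ccc([N+](=O)[O-])cc3)c2O)O1` differs from compound 3 by nitro in place of bromo on an aromatic carbon. Within the data shown here, no measured step changes bromo into nitro, and the only sized step concerns chloro against dimethylamino, so it bears on compound 4 only loosely. Compound 4 is expected to sit near compound 2 in this assay, within the scatter of it. The estimate for compound 4 is 80000 nM, with a range from 25000 nM to 300000 nM.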

Compound 4, half-maximal cytotoxic concentration: 106000 nM
For compound 4 the middle estimate is 1.3-fold (0.12 log units) below the measured one, within the range that was stated.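

In this assay, nitro in place of chloro on this aromatic carbon gives a 1.1-fold higher number from compound 2 to compound 4 (0.06 log units; within the scatter), so the two groups cannot be told apart at this position. Nitro in place of dimethylamino gives an at least 3.7-fold lower number from compound 1 to compound 4 (0.57 log units; beyond the scatter), which means that dimethylamino now stands apart from two different groups here rather than from chloro alone. The entry for compound 1 is a limit and not a number, so both steps from it are sized only against that limit: the limit of > 400000 nM in this assay, at which 1 of the 4 values shown sits.

Steps to or from compound 3 cannot be read, so the place of bromo relative to chloro and nitro stays unknown. Going by these compounds, it also remains open whether the separation belongs to dimethylamino alone, or whether an unsubstituted amino group or a methoxy group on this carbon would fall with dimethylamino or with chloro and nitro.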